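A few compounds are considered here, and "the series" means these few. Any claim that something is new, unique, unknown or untested is made for them only; others in the source may bear on it.

A small set of compounds built on one shared core has been examined in an assay on MDA-MB-231 cells for binding affinity to C-X-C chemokine receptor type 4 (Homo sapiens), read by immunofluorescence and microscopy, with stated times of 10 min and 30 min; a higher number here means that more compound is needed for the effect, a lower number that less compound is needed. Compound 1 `Cc1ccc(S(=O)(=O)NCc2ccc(CNC(=O)c3ccc(Cl)cc3)cc2)cc1` gives 10 nM, the lowest of the three numbers. Compound 2 `O=C(NCc1ccc(CNS(=O)(=O)c2ccccc2)cc1)c1ccc([N+](=O)[O-])cc1` gives 100 nM, and compound 3 `O=C(NCc1ccc(CNS(=O)(=O)c2ccccc2)cc1)c1ccccc1F` gives 1000 nM. Compound 1 and compound 2 differ in more than one place, so their values can only be set side by side: compound 2 sits at a higher number than compound 1. Among the compounds with values here, the one measured single-point step, a 10-fold higher number from compound 2 to compound 3 (1.00 log units; beyond the scatter), alters the ring attached to the carbonyl, putting 2-fluorophenyl in place of 4-nitrophenyl.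

Compound 4 `Cc1ccc(C(=O)NCc2ccc(CNS(=O)(=O)c3ccc(C)cc3)cc2)cc1` differs from compound 1 by methyl in place of chloro on an aromatic carbon. This change also sits on the ring attached to the carbonyl, the same part of the core where the step from compound 2 to compound 3 had a clear effect. Within the data shown here, that step, however, moved a different group to a different place, so it shows only that this ring matters, not which way a swap of chloro for methyl should go. Among the measured compounds shown here, no measured step covers this swap. A small step is therefore expected in this assay, likely near the scatter, described by the estimate a 2.0-fold higher number from compound 1 to compound 4 (0.30 log units; within the scatter). Compound 4 is estimated at 20 nM, with a range from 5 nM to 80 nM.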

Compound 4, effective concentration (reported as EC, without a stated level of effect): 1000 nM
Compound 4: the middle estimate sits 50-fold (1.70 log units) below what was measured, outside the stated range (above it).
By their numbers in this assay, from the lowest: compound 1; then compound 2; then compounds 3 and 4 (each within the scatter of the next).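

In this assay, replacing one substituent with another at this position has a large effect: a 100-fold higher number from compound 1 to compound 4 (2.00 log units; beyond the scatter). Chloro and methyl each count as one heavy atom, with no hydrogen-bond donors or acceptors and no net charge, yet with the rest of compound 1 unchanged, this swap on an aromatic carbon para to a large group moves the number well beyond the scatter. The earlier step, which changed a different group at a different place, showed only that the ring attached to the carbonyl matters, whereas this pair shows that 4-chlorophenyl and 4-methylphenyl are far from interchangeable here, and no measurement shown explains the gap.

As far as these compounds go, it remains open whether the higher number is specific to methyl or extends to other replacements for chloro; a bromo or methoxy group at this position would help to separate those two readings. From the compounds shown here alone, it is also open whether the same swap would have an effect of similar size on a compound with a different group on the sulfonyl side of the core.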